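The source may hold more compounds than are shown below. What is called first, only, known or untested is meant among the compounds shown, and "the series" means these compounds.

Measured so far in an assay on isolated protein (strain Charles River) for antagonist activity at histamine H2 receptor (Rattus norvegicus); a lower number here means that less compound is needed, a higher number that more compound is needed for the effect:
- compound 1 `Cc1cc(C)c2ccc(=O)n(CCN)c2n1`, giving 33.8 ug/mL
- compound 2 `CCN(CC)CCn1c(=O)ccc2c(C)cc(C)nc21`, giving 1.12 ug/mL

Among the compounds with values here, of these two numbers compound 2 stands lowest; its only neighbour is compound 1, and the step of a 30-fold lower number from compound 1 to compound 2 (1.48 log units; beyond the scatter) separates them. Compound 3 `Cc1cc(C)c2ccc(=O)n(CCN(C(C)C)C(C)C)c2n1` has not yet been measured. It differs from compound 2 by diisopropylamino in place of diethylamino on a saturated chain carbon, two bonds along the chain from an aromatic nitrogen. Within the data shown here, the only measured step that touches the same place is a 30-fold lower number from compound 1 to compound 2 (1.48 log units; beyond the scatter), where amino gave way to diethylamino. That step shows what the first enlargement of the chain amine did, but nothing measured here carries diisopropylamino, so how a further enlargement of the same amine behaves is not shown by the series. Among the measured compounds shown here, with only that one step to go on, the expectation for compound 3 in this assay is a number near that of compound 2, allowing for movement in either direction, which means a step of a 1.3-fold higher number from compound 2 to compound 3 (0.13 log units; within the scatter) that is expected to stay within the scatter. Compound 3 is therefore estimated at 1.5 ug/mL, with a range from 0.5 ug/mL to 5 ug/mL.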

Compound 3, half-maximal effective concentration: 1.44 ug/mL
Beside the measured number, compound 3's estimate is 1.0-fold (0.02 log units) above it; low and high end bracket the measured number.
By their numbers in this assay, from the lowest: compounds 2 and 3 (each within the scatter of the next); then compound 1.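

In this assay, diisopropylamino in place of diethylamino on a saturated chain carbon, two bonds along the chain from an aromatic nitrogen, gives a 1.3-fold higher number from compound 2 to compound 3 (0.11 log units; within the scatter), so this change does not separate the two compounds and the further enlargement of the amine leaves the number within the scatter. The large difference from the unsubstituted amino group is therefore not tied to diethylamino alone: a 23-fold lower number from compound 1 to compound 3 (1.37 log units; beyond the scatter), a step beyond the scatter, as is a 30-fold lower number from compound 1 to compound 2 (1.48 log units; beyond the scatter), and in this series both dialkylamino groups stand apart from amino in the same direction. No measurement at hand bears on what lies behind these steps.

The compounds shown leave open where between amino and diethylamino the large step arises, which a single-substituent amine such as ethylamino would help to place, and whether the level held by compound 2 and compound 3 persists with a larger dibutylamino group or a ring amine such as piperidine or morpholine. They also leave open how a longer chain between the aromatic nitrogen and the amine would behave in this assay.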